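A few compounds are considered here, and "the series" means these few. Any claim that something is new, unique, unknown or untested is made for them only; others in the source may bear on it.

Compound 3 `N/C(=N\NC(=S)N1CCCCC1)c1ccccn1` gives 38.6% in a functional assay on MCF7 cells (Homo sapiens) for cytotoxicity, read by MTT assay, with a stated time of 72 h, tested at 3 uM; a higher number here means more inhibition of growth at the concentration tested, a lower number less inhibition of growth. Compound 2 `Cc1ccnc(/C(N)=N/NC(=S)N2CCSCC2)c1` gives 33.8% in this assay, which is within the scatter of that, while compound 1 `Cc1ccnc(/C(N)=N/NC(=S)N2CCOCC2)c1` gives 5.07% in this assay, beyond the scatter on the low side. Among the measured compounds shown here, the one measured step, a number 28.7 percentage points higher from compound 1 to compound 2 (beyond the scatter), exchanges the ring on the thiocarbonyl carbon and so does not bear on the change to compound 4 `Cc1ccnc(/C(N)=N/NC(=S)N2CCCCC2)c1`, which is methyl in place of hydrogen on an aromatic carbon. For the measured compounds named here, no measured pair differs by a methyl on the ring, so nothing sets a size or direction for this step. Compound 4 is expected to sit close to compound 3, with an expected step of a number 0.6 percentage points lower from compound 3 to compound 4 (within the scatter). The estimate for compound 4 is 38%, with a range from 24% to 52%.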

Compound 4, percent growth inhibition at one concentration: 29.4%
The estimate for compound 4 lay 8.6 percentage points above the measured number; low and high end bracket the measured number.
By their numbers in this assay, from the lowest: compound 1; then compounds 4, 2 and 3 (each within the scatter of the next).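

In this assay, among the compounds shown here, the first reading at this position, a number 9.2 percentage points lower from compound 3 to compound 4 (within the scatter), shows that methyl on the aromatic carbon opposite the ring nitrogen brings no change beyond the scatter. With the methyl present, a number 4.4 percentage points lower from compound 2 to compound 4 (within the scatter) places piperidin-1-yl level with thiomorpholin-4-yl, while a number 24.3 percentage points higher from compound 1 to compound 4 (beyond the scatter) leaves morpholin-4-yl on the low side of both. Nothing measured explains these differences. Open, as far as these compounds go, is whether the methyl step holds with morpholin-4-yl or thiomorpholin-4-yl on the thiocarbonyl carbon, and what a methoxy, an amine or a carboxylic acid would give in place of the methyl.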